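The compounds below may be only part of what the source reports. "The series", "measured", "known", "first", "only" and "open" are said of these compounds alone.

Of the compounds shown here, two have been measured in an ADME assay on a cell-free system (plasma, Homo sapiens) for metabolic stability, with Plasma (Rattus norvegicus) as the target, read by HPLC, at pH 7.4; a lower number here means that the compound disappears faster, a higher number that the compound lasts longer. Within the data shown here, compound 1 `CC(=O)Oc1ccccc1C(=O)O[C@H]1CO[C@H]2[C@@H]1OC[C@H]2OC(C)=O` gives 0.0095 h, and compound 2 `CC(=O)Oc1ccccc1C(=O)O[C@H]1CO[C@H]2[C@@H]1OC[C@H]2OC(=O)c1ccc([N+](=O)[O-])cc1` gives 0.0227 h, the higher of the two numbers; the only measured step, a 2.4-fold higher number from compound 1 to compound 2 (0.38 log units; beyond the scatter), separates them. Compound 3 `CC(=O)Oc1ccccc1C(=O)O[C@H]1CO[C@H]2[C@@H]1OC[C@H]2OC(=O)CCO[N+](=O)[O-]` is not yet measured. It differs from compound 2 in one place: 2-(nitrooxy)ethyl in place of 4-nitrophenyl on a carbonyl carbon. The step from compound 1 to compound 2 is the one that bears on this change, since it involves the same carbonyl carbon and the same 4-nitrophenyl group, here leaving rather than entering. The group that enters has no ring, like the methyl of compound 1, so the number is expected to move back toward that of compound 1, with a 1.9-fold lower number from compound 2 to compound 3 (0.28 log units; within the scatter) as the expected step in this assay. Compound 3 is therefore estimated at 0.012 h, within a range from 0.006 h to 0.024 h.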

Compound 3, half-life: 0.0217 h
For compound 3 the middle estimate is 1.8-fold (0.26 log units) below the measured one; low and high end bracket the measured number.
By their numbers in this assay, from the lowest: compound 1; then compounds 3 and 2 (each within the scatter of the next).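

In this assay there is a 1.0-fold lower number from compound 2 to compound 3 (0.02 log units; within the scatter) at this carbonyl carbon, so 2-(nitrooxy)ethyl, which has no ring, cannot be told apart from 4-nitrophenyl. The data also show a 2.3-fold higher number from compound 1 to compound 3 (0.36 log units; beyond the scatter) for the same change of end group, which means that a six-membered aromatic ring is not required for a number above that of compound 1, and that methyl is the group that stands apart among these three. Nothing available explains why two such different groups give matching numbers.

From the compounds shown here alone, it remains open whether the nitrooxy group matters or only a chain longer than methyl, which a plain propyl chain would help to separate. Also open, going by these compounds, is how a longer nitrooxy chain, or a chain ending in an amine or a carboxylic acid, would behave at this position.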